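Compound 2 to compound 4: a larger group on the core

The source may hold more compounds than are shown below. What is called first, only, known or untested is meant among the compounds shown, and "the series" means these compounds.

Measured in an ADME assay on MDCK-II cells (Canis lupus familiaris) for permeability; a lower number here means that the compound crosses the layer more slowly, a higher number that the compound crosses the layer faster:
compound 1 `Cc1ccc(NC(=O)c2cc(Oc3ccc(S(C)(=O)=O)cc3)cc(OC(C)C)c2)nc1`: 4.4 10^-6 cm/s
compound 2 `CC(C)Oc1cc(Oc2ccc(S(C)(=O)=O)cc2)cc(-c2cccc(=O)[nH]2)c1`: 18 10^-6 cm/s
compound 3 `CC(C)Oc1cc(Oc2ccc(S(C)(=O)=O)cc2)cc(-c2ncc(C(C)C)c(=O)[nH]2)c1`: "not determined" (no result reported)

In this assay compound 2 holds the higher of the two numbers, at 18 10^-6 cm/s. Compound 4 `COc1cnc(-c2cc(Oc3ccc(S(C)(=O)=O)cc3)cc(OC(C)C)c2)[nH]c1=O` differs from it by a group of 9 heavy atoms (5 carbon, 2 nitrogen, 2 oxygen; one six-membered aromatic ring with 2 hetero atoms) in place of a group of 7 heavy atoms (5 carbon, 1 nitrogen, 1 oxygen; one six-membered aromatic ring with 1 hetero atom), on an aromatic carbon, on an aromatic carbon of a six-membered aromatic ring of carbon only. Among the measured compounds shown here, one measured step bears on this place: a 4.1-fold higher number from compound 1 to compound 2 (0.61 log units; beyond the scatter). There, the group with more heavy atoms went with the lower number. Compound 3 adds no number. For the measured compounds named here, a single step is thin evidence, so a modest fall is expected, no larger than that step. The estimated change is a 2.0-fold lower number from compound 2 to compound 4 (0.30 log units; within the scatter). For compound 4 the expected value is 9 10^-6 cm/s, within an estimated range from 3.5 10^-6 cm/s to 20 10^-6 cm/s.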

Compound 4, apparent permeability: 3.9 10^-6 cm/s
Compound 4: the middle estimate sits 2.3-fold (0.36 log units) above what was measured; the range from low to high includes it.
By their numbers in this assay, from the lowest: compounds 4 and 1 (each within the scatter of the next); then compound 2.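

At this aromatic carbon, the exchange to the group with 3 hydrogen-bond acceptors gives a 4.6-fold lower number from compound 2 to compound 4 (0.66 log units; beyond the scatter) in this assay, a fall beyond the scatter and larger than the modest fall expected. The step of a 1.1-fold lower number from compound 1 to compound 4 (0.05 log units; within the scatter) lies within the scatter, so two different groups at this place read alike, and only the group of compound 2 stands apart. The data shown offer no measurement that explains this fall.

From the compounds shown here alone, the second ring nitrogen and the extra oxygen enter together, so their separate shares remain open. Also open, going by these compounds, is how an amine or a carboxylic acid on that ring would read.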